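A few compounds are considered here, and "the series" means these few. Any claim that something is new, unique, unknown or untested is made for them only; others in the source may bear on it.

Measured compounds:
- compound 1 `O=S(=O)(CC1=NCCO1)C1C(c2ccc(Cl)cc2)=NN(c2ccccc2)C1c1ccc(Cl)cc1`: in a functional assay, read by Griess assay, with a stated time of 150 min, tested at 50 ug/mL (on this read-out higher numbers stand for a stronger effect at the one concentration tested and lower numbers for a weaker effect), compound 1 gives "not active" (no number reported)
- compound 2 `COc1ccc(-c2nn(-c3ccccc3)c(-c3ccc(C)cc3)c2S(=O)(=O)CC2=NCCO2)cc1`: in this assay compound 2 gives 61.6%

Compound 1 is reported without any number in this assay, only as showing no effect, so it stands at the bottom of what has been seen, while compound 2 stands with a clear measured effect. For the measured compounds named here, no pair of compounds differing in one place has been measured, so the size of any single change is still unknown.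

Compound 3 `O=S(=O)(CC1=NCCS1)C1C(c2ccc(Cl)cc2)=NN(c2ccccc2)C1c1ccc(Cl)cc1` differs from compound 1 in one place: a group of 5 heavy atoms (3 carbon, 1 nitrogen, 1 sulfur; one five-membered non-aromatic ring with 2 hetero atoms) in place of a group of 5 heavy atoms (3 carbon, 1 nitrogen, 1 oxygen; one five-membered non-aromatic ring with 2 hetero atoms), on a saturated chain carbon bound to a sulfonyl sulfur. Going by the values given here, with no measured step of this kind to lean on, the expected change is small, most likely none beyond the usual scatter, and the starting point is a compound that gave no effect at all.

Compound 3 is therefore expected to give about 12% in this assay, with a range from 0% to 40%, and it may well again be reported without a number.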

Compound 3, a percentage reported as activity, at one concentration (the size of the read-out at that concentration, not a potency): "not active" (no number reported)
Compound 3: no number reported, and the estimate cannot be compared.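

Compound 1 and compound 3 are both reported without a number, so no step can be read between them, and no measured evidence bears on this result. From the compounds shown here alone, what the swap of these five-membered rings would do in a compound with a measured effect, such as compound 2, remains open.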